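The compounds below may be only part of what the source reports. "The series", "measured", "known", "first", "only" and "open" are said of these compounds alone.

Measured compounds:
- compound 1 `Nc1ccccc1NC(=O)c1ccc(CSC(=S)N2CCN(c3ccc(Cl)cc3)CC2)cc1`: 51.2%
- compound 2 `N#Cc1ccc(N2CCN(C(=S)SCc3ccc(C(=O)Nc4ccccc4N)cc3)CC2)cc1`: 71.6%
- compound 3 `Nc1ccccc1NC(=O)c1ccc(CSC(=S)N2CCN(c3ccncc3)CC2)cc1`: 77%

In a functional assay on HeLa cells (Homo sapiens) for antiproliferative activity, read by CCK-8 assay, with a stated time of 72 h, tested at 2 uM (on this read-out higher numbers stand for a stronger effect at the one concentration tested and lower numbers for a weaker effect), compound 3 gives the highest of the three numbers. Its nearest neighbour is compound 2, and the step of a number 5.4 percentage points higher from compound 2 to compound 3 (within the scatter) lies within the scatter, so the two cannot be ordered. The step of a number 25.8 percentage points higher from compound 1 to compound 3 (beyond the scatter) lies beyond the scatter, as does a number 20.4 percentage points higher from compound 1 to compound 2 (beyond the scatter).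

Compound 4 `Nc1ccccc1NC(=O)c1ccc(CSC(=S)N2CCN(C3CCCCC3)CC2)cc1` differs from compound 3 in one place: cyclohexyl in place of pyridin-4-yl on an amine nitrogen in a ring. Among the measured compounds shown here, none of the measured steps covers this change directly; the closest is the step from compound 1 to compound 3, in which the whole group on the ring nitrogen was exchanged for pyridin-4-yl with a modest rise. As far as these compounds go, the three measured groups on that nitrogen are all aromatic, so the move to a non-aromatic cyclohexyl is untested here. Given that swapping the group on this nitrogen has shifted the read-out by modest amounts, a modest step downward in this assay is expected, as a number 17 percentage points lower from compound 3 to compound 4 (beyond the scatter), with wide uncertainty. Compound 4 is therefore estimated at 60%, in a range from 40% to 78%.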

Compound 4, a percentage reported as inhibition, at one concentration (the size of the read-out at that concentration, not a potency): 30.6%
Estimate against measurement, compound 4: 29.4 percentage points above; measured number outside the range, below it.
By their numbers in this assay, from the lowest: compound 4; then compound 1; then compounds 2 and 3 (each within the scatter of the next).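

In this assay, cyclohexyl on this amine nitrogen in a ring gives a lower number than each of the three aromatic groups, and every step is beyond the scatter (a number 46.4 percentage points lower from compound 3 to compound 4 (beyond the scatter); a number 41 percentage points lower from compound 2 to compound 4 (beyond the scatter); a number 20.6 percentage points lower from compound 1 to compound 4 (beyond the scatter)). Pyridin-4-yl and cyclohexyl have the same heavy-atom count, so that count does not separate them, whereas they do differ in ring aromaticity and in the ring nitrogen; the 4-chlorophenyl of compound 1 has no ring nitrogen and still stands above compound 4, so a ring nitrogen is not required for a number above that of cyclohexyl. No available evidence explains the drop at this position.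

The compounds shown leave open whether a non-aromatic ring carrying a hetero atom, such as tetrahydropyran-4-yl or piperidin-4-yl, would behave like cyclohexyl or like the aromatic groups. They also leave open how an unsubstituted phenyl would compare, and, with one concentration tested, whether the stronger and weaker effects seen at that concentration would hold at other concentrations.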